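Amide replacement on a bis-sulfonamide piperidine scaffold

The compounds below may be only part of what the source reports. "The series", "measured", "known", "first", "only" and "open" are said of these compounds alone.

Compound 1 `CCN(CC)C(=O)[C@@H]1CCCN(S(=O)(=O)c2ccc(S(=O)(=O)N(CC)CC)cc2)C1` — 6400 nM
Compound 2 `CCOC(=O)[C@H]1CCN(S(=O)(=O)c2ccc(S(=O)(=O)N(CC)CC)cc2)C1` — 29200 nM

In a functional assay on MIA PaCa-2 cells (Homo sapiens) for inhibition, read by MTT assay, with a stated time of 7 days (on this read-out lower numbers stand for stronger inhibition and higher numbers for weaker inhibition), compound 1 gives 6400 nM, the lowest of the two numbers available. Compound 2, the ethyl ester, gives 29200 nM, a gap from compound 1 that lies beyond the scatter.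

Compound 3 `CCN(CC)S(=O)(=O)c1ccc(S(=O)(=O)N2CCC[C@@H](C(=O)NC3CN(C(=O)NC(C)(C)C)C3)C2)cc1` has not yet been measured. It differs from compound 1 in one place: (1-((tert-butyl)carbamoyl)azetidin-3-yl)amino in place of diethylamino on a carbonyl carbon. Among the measured compounds shown here, no measured pair shows this change, so its effect is not known from the data. For the measured compounds named here, the only comparison at hand, between compound 1 and compound 2, concerns the carbonyl substituent as well, and there the amide of compound 1 stands lower than the ester. On that basis a modest gain is expected for compound 3, with the step from compound 1 estimated as a 1.8-fold lower number from compound 1 to compound 3 (0.26 log units; within the scatter). Compound 3 is therefore expected to give 3500 nM, with a range from 900 nM to 14000 nM.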

Compound 3, half-maximal inhibitory concentration: 3400 nM
Estimate against measurement, compound 3: 1.0-fold (0.01 log units) above, within the range that was stated.
By their numbers in this assay, from the lowest: compounds 3 and 1 (each within the scatter of the next); then compound 2.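

In this assay, putting (1-((tert-butyl)carbamoyl)azetidin-3-yl)amino in place of diethylamino on a carbonyl carbon gives a 1.9-fold lower number from compound 1 to compound 3 (0.27 log units; within the scatter) and so leaves compound 1 and compound 3 indistinguishable on this read-out. The position therefore tolerates a much larger group, one that brings a four-membered ring and hydrogen-bond donors where diethylamino has none, without a change in inhibition beyond the scatter. Nothing measured here explains this tolerance or links it to any property of the group.

The compounds shown leave open whether a morpholine or a longer alkyl chain on this carbonyl carbon would give a number clearly different from those of compound 1 and compound 3. They also leave open what an ethyl ester does on the core of compound 1, since compound 2 differs from compound 1 in more than one place.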